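A few compounds are considered here, and "the series" means these few. Any claim that something is new, unique, unknown or untested is made for them only; others in the source may bear on it.

In an assay on isolated protein (Cavia porcellus) with cysteinyl leukotriene receptor (Homo sapiens) as the target (a higher number here means a more potent compound, by a factor of ten per unit of this negative logarithm, a lower number a less potent compound), compound 1 `COc1cc(C(=O)NS(=O)(=O)c2ccccc2)ccc1Cc1cn(C)c2ccc(NC(=O)OC3CCCC3)cc12` gives 9.69. Compound 2 `CCCn1cc(Cc2ccc(C(=O)O)cc2OC)c2cc(NC(=O)OC3CCCC3)ccc21` gives 7.72, and compound 3 `COc1cc(C(=O)O)ccc1Cn1ccc2ccc(NC(=O)CC3CCCC3)cc21` gives 7.68. Compound 2 thus holds the second highest of the three numbers: its value and that of compound 3 lie within the usual scatter of each other, while compound 1 sits far above it, a gap well beyond the scatter. Compound 1 differs from compound 2 in more than one place, so no single change can be tied to that gap. Compound 4 `COc1cc(C(=O)O)ccc1Cc1c[nH]c2ccc(NC(=O)OC3CCCC3)cc12` arises from compound 2 by hydrogen in place of propyl on an aromatic nitrogen. Within the data shown here, no measured pair shows this change on its own, so the step of a number 0.22 log units lower from compound 2 to compound 4 (within the scatter) is expected to be modest, possibly none beyond the scatter. Compound 4 is therefore estimated at 7.5, within 6.8 to 8.2.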

Compound 4, negative logarithm of the antagonist equilibrium constant: 7.32
Compound 4: middle estimate off by 0.18 log units, on the high side; the range from low to high includes it.
By their numbers in this assay, from the lowest: compound 4; then compounds 3 and 2 (each within the scatter of the next); then compound 1.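

In this assay, among these compounds, this is the first single change that can be read at this position: a number 0.40 log units lower from compound 2 to compound 4 (beyond the scatter). The aromatic nitrogen therefore needs no chain for binding to be kept, although hydrogen there gives a lower number than propyl. No measurement here explains the drop. Going by these compounds, whether an ethyl or butyl chain on this nitrogen would give a number nearer compound 2 or compound 4 remains open, as does the effect of a benzyl group there.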